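Swapping Bromo for 4-Methoxyphenyl on a Pyridone-Free Reading

The source may report more compounds than this note shows. Statements on the series, on what has been measured and on what is new or still open speak of the compounds shown alone.

Two compounds frame this step in a functional assay on U-937 cells (Homo sapiens) for inhibition, read by scintillation counting, with a stated time of 15 min; a lower number here means a stronger inhibitor, a higher number a weaker inhibitor. Compound 2 `O=C(NC1CCCCCC1)c1c(-c2ccccc2)c(Br)cn(Cc2ccc(F)cc2)c1=O` reaches only a limit of the assay, reported as > 10000 nM, so no true potency is known for it. Compound 3 `COc1ccc(-c2cn(Cc3ccc(F)cc3)c(=O)c(C(=O)NC3CCCCCC3)c2-c2ccccc2)cc1` keeps the phenyl group of compound 2 and puts 4-methoxyphenyl in place of bromo on an aromatic carbon, ortho to that phenyl group (4-methoxyphenyl in place of bromo on an aromatic carbon).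

Going by the values given here, the only numerical guide is compound 1 `COc1ccc(-c2cn(Cc3ccc(F)cc3)c(=O)c(C(=O)NC3CCCCCC3)c2C)cc1`, which also carries a 4-methoxyphenyl group but has a methyl group and no phenyl group. In this assay compound 1 gives 280 nM. The two measured compounds differ in more than one place, so this comparison cannot isolate the effect of either change. Even so, compound 3 shares one feature with each of them, and a clear gain in inhibition over compound 2 is expected, beyond the usual scatter. From the compounds shown here alone, the expected step is an at least 14-fold lower number from compound 2 to compound 3 (1.15 log units; beyond the scatter), although its true size stays open while compound 2 has only a limit. For compound 3 the estimated value in this assay is 700 nM, with an expected range from 120 nM to 5000 nM.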

Compound 3, half-maximal inhibitory concentration: > 10000 nM
Compound 3 ended at the assay's limit; the forecaster's own chance of this, stated with the estimate: 20%; middle value at least 14-fold (1.15 log units) from the limit.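

In this assay, putting phenyl in place of methyl on the aromatic carbon, with 4-methoxyphenyl kept on the shared core, gives an at least 35-fold higher number from compound 1 to compound 3 (1.55 log units; beyond the scatter), a large loss of inhibition that counts as a lower bound. This shows that 4-methoxyphenyl does not secure inhibition by itself: it comes with a measurable potency in compound 1, which carries methyl, but not in compound 3, which carries phenyl, so the group on the carbon ortho to this position matters a great deal. The exchange of bromo for 4-methoxyphenyl itself cannot be read, and compound 2 and compound 3 both give only a limit and no true potency: the limit of > 10000 nM in this assay, at which 2 of the 3 values shown sit.

The compounds shown leave open whether an ethyl or cyclopropyl group on the carbon that holds methyl in compound 1 would keep inhibition, and so how much of the loss appears only once that group is as large as phenyl. They also leave open what bromo or a smaller group such as methoxy would do at this position when methyl, not phenyl, stands beside... 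

Correction to the final sentence: They also leave open what bromo or a methoxy group would do at this position in a compound that keeps the methyl group of compound 1.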